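Configuration Alone Moves Cytotoxicity Across a Shared Core

The source may hold more compounds than are shown below. What is called first, only, known or untested is meant among the compounds shown, and "the series" means these compounds.

Two compounds built from the same atoms and bonds, compound 1 `O=C(c1ccc(O)cc1O)[C@H]1[C@H](c2ccccc2)[C@H](C(=O)c2ccc(O)cc2O)[C@H]1c1ccccc1` and compound 2 `O=C(c1ccc(O)cc1O)[C@H]1[C@H](c2ccccc2)[C@H](C(=O)c2ccc(O)cc2O)[C@@H]1c1ccccc1`, differ only in how the groups on the shared core are arranged in space. In a functional assay on PC-3 cells (Homo sapiens) for cytotoxicity, read by MTT assay, with a stated time of 48 h, tested at 5 uM (on this read-out lower numbers stand for a weaker effect and higher numbers for a stronger effect at the one concentration tested), compound 1 gives 29.6%, and compound 2 gives 12.3%, the lowest of the two numbers. The step of a number 17.3 percentage points lower from compound 1 to compound 2 (beyond the scatter) rests on (the fact that compounds 1 and 2 differ only in the configuration as drawn), so arrangement in space alone can shift this read-out by a modest amount. Compound 3 `O=C(c1ccc(O)cc1O)[C@H]1[C@H](c2ccccc2)[C@@H](C(=O)c2ccc(O)cc2O)[C@@H]1c1ccccc1` is a further arrangement of the same atoms: the two compounds have the same atoms and bonds and differ only in configuration as drawn: 3 of 4 stereo elements differ; a stereocentre at a saturated ring carbon is drawn S in compound 2 and r in compound 3; a stereocentre at a saturated ring carbon is drawn s in compound 2 and r in compound 3; a stereocentre at a saturated ring carbon is drawn R in compound 2 and r in compound 3. Within the data shown here, only that one measured step bears on this change, and it shows the size such a change can have but not its direction; a shift of similar size either way, or none beyond the scatter, is possible. Compound 3 is therefore expected to give 20%, within 5% to 40% in this assay. That estimate means the expected step is a number 7.7 percentage points higher from compound 2 to compound 3 (within the scatter).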

Compound 3, a percentage reported as activity, at one concentration (the size of the read-out at that concentration, not a potency): 12.8%
Beside the measured number, compound 3's estimate is 7.2 percentage points above it, and the stated range covers the measured number.
By their numbers in this assay, from the lowest: compounds 2 and 3 (each within the scatter of the next); then compound 1.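

Compound 3 is the mirror image of compound 1, with all four stereo elements inverted, and the step is a number 16.8 percentage points lower from compound 1 to compound 3 (beyond the scatter) in this assay. Mirror-image forms of this core therefore do not read alike here, and the gap rests on arrangement in space alone: the fact that compounds 1 and 3 differ only in the configuration as drawn.

Compound 2 and compound 3 show the other side: the step is a number 0.5 percentage points higher from compound 2 to compound 3 (within the scatter) even though three of the four stereo elements differ, so a large change in configuration as drawn need not move this number: the fact that compounds 2 and 3 differ only in the configuration as drawn.

On these data alone, whether the gap between arrangements would survive a change of group on the shared core, such as a methoxy group or an amine on the phenyl rings, stays open. With one concentration per compound, these numbers show only a stronger or weaker effect at that concentration.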